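The source may report more compounds than this note shows. Statements on the series, on what has been measured and on what is new or still open speak of the compounds shown alone.

Compound 1 `O=C1O/C(=C\Cn2cnc3cncc(Br)c32)C(OCc2ccccc2)=C1OCc1ccccc1`, compound 2 `O=C1NC(O)(CCn2cnc3cncc(Br)c32)C(OCc2ccccc2)=C1OCc1ccccc1` and compound 3 `O=C1NC(O)(CCn2cnc3ccnc(Cl)c32)C(OCc2ccccc2)=C1OCc1ccccc1` have been measured; compound 4 `O=C1O/C(=C\Cn2cnc3ccnc(Cl)c32)C(OCc2ccccc2)=C1OCc1ccccc1` has not. In a functional assay on MIA PaCa-2 cells (Homo sapiens) for antiproliferative activity, read by MTT assay, with a stated time of 72 h (on this read-out lower numbers stand for stronger inhibition and higher numbers for weaker inhibition), compound 1 gives 22600 nM, compound 2 gives 48700 nM and compound 3 gives 60000 nM. Compound 1 stands lowest of the three, with gaps to compound 2 and compound 3 that are beyond the scatter. Compound 2 and compound 3 lie within the scatter of each other. How the core of compound 1 differs from the core of compound 2 is not broken down here.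

From compound 2 to compound 3 the change is a group of 10 heavy atoms (6 carbon, 3 nitrogen, 1 chlorine; one five-membered aromatic ring with 2 hetero atoms, one six-membered aromatic ring with 1 hetero atom) in place of a group of 10 heavy atoms (6 carbon, 3 nitrogen, 1 bromine; one five-membered aromatic ring with 2 hetero atoms, one six-membered aromatic ring with 1 hetero atom), on a saturated chain carbon, two bonds along the chain from a saturated ring carbon, and the step is a 1.2-fold higher number from compound 2 to compound 3 (0.09 log units; within the scatter). From compound 1 to compound 4 the change is a group of 10 heavy atoms (6 carbon, 3 nitrogen, 1 chlorine; one five-membered aromatic ring with 2 hetero atoms, one six-membered aromatic ring with 1 hetero atom) in place of a group of 10 heavy atoms (6 carbon, 3 nitrogen, 1 bromine; one five-membered aromatic ring with 2 hetero atoms, one six-membered aromatic ring with 1 hetero atom), on a saturated chain carbon bound to a double-bonded chain carbon. This is the same kind of change, not the same one: in compound 4 the group sits on a saturated chain carbon bound to a double-bonded chain carbon, whereas in compound 3 it sits on a saturated chain carbon, two bonds along the chain from a saturated ring carbon. Because a 1.2-fold higher number from compound 2 to compound 3 (0.09 log units; within the scatter) is within the scatter, a similarly small step is expected here, a 1.2-fold higher number from compound 1 to compound 4 (0.08 log units; within the scatter). Compound 4 is accordingly estimated at 27000 nM in this assay, between 12000 nM and 60000 nM.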

Compound 4, half-maximal inhibitory concentration: > 100000 nM
Compound 4 ended at the assay's limit; the forecaster's own chance of this, stated with the estimate: 5%; middle value at least 3.7-fold (0.56 log units) from the limit.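

In this assay, putting the chlorine-bearing group in place of the bromine-bearing group on a saturated chain carbon bound to a double-bonded chain carbon gives an at least 4.4-fold higher number from compound 1 to compound 4 (0.64 log units; beyond the scatter). The same kind of change does not carry over at the same size from one core to the other: the same change on two cores in this assay, a 1.2-fold higher number (0.09 log units; within the scatter) from compound 2 to compound 3 and an at least 4.4-fold higher number (0.64 log units; beyond the scatter) from compound 1 to compound 4, at least 3.5-fold (0.55 log units) apart, beyond the scatter of two such steps. The reading for compound 4 is a limit of the assay and not a number, which leaves only a lower bound on the step, and one pair on each core does not show which feature of the core accounts for the gap: the limit of > 100000 nM in this assay, at which 1 of the 4 values shown sits.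

The compounds shown leave open whether the gap between the two cores holds for other groups on the chain, since only this one exchange can be compared. Also open, from the compounds shown here alone, is how the two cores respond when an amine or a methyl stands in place of the bromine or the chlorine, and whether a longer chain alters the picture.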